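This account rests on a few compounds, and the source may have more. Where it says the series, first, only, none or still open, it means among the compounds named here.

In an assay on isolated protein for inhibition of retinal dehydrogenase 2 (Homo sapiens), tested at 5 uM (on this read-out lower numbers stand for less inhibition and higher numbers for more inhibition at the one concentration tested (going by the name of the read-out)), compound 1 `COCc1ccc(-n2c(SC(C)c3ccccc3)nc3c(cnn3C)c2=O)cc1` gives 61%. Among the three measured numbers this is the second highest: compound 2 `CC(Sc1nc2c(cnn2C)c(=O)n1-c1ccccc1)c1ccncc1` gives 69%, which lies within the scatter of compound 1, while compound 3 `COc1ccc(C(C)Sc2nc3c(cnn3C)c(=O)n2-c2ccccc2)cc1` gives 41%, a gap beyond the scatter. Among the measured compounds shown here, the one measured single-place step, a number 28 percentage points lower from compound 2 to compound 3 (beyond the scatter), concerns the saturated chain carbon bound to a sulfur. Compound 4 `COCCc1ccc(-n2c(SC(C)c3ccccc3)nc3c(cnn3C)c2=O)cc1` differs from compound 1 at another place: methoxymethyl in place of methoxy on a saturated chain carbon bound to an aromatic carbon, so that 4-(methoxymethyl)phenyl becomes 4-(2-methoxyethyl)phenyl. For the measured compounds named here, no measured step touches this place, so the change is expected to bring no step beyond the scatter, a number 1 percentage points lower from compound 1 to compound 4 (within the scatter). Compound 4 is therefore estimated at 60%, within 42% to 76%.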

Compound 4, a percentage reported as inhibition, at one concentration (the size of the read-out at that concentration, not a potency): 54%
Beside the measured number, compound 4's estimate is 6 percentage points above it; low and high end bracket the measured number.
By their numbers in this assay, from the lowest: compound 3; then compounds 4, 1 and 2 (each within the scatter of the next, the first and the last beyond it).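

Among the compounds shown here, compound 1 and compound 4 give the first measured step at this place on the phenyl group. In this assay, 4-(2-methoxyethyl)phenyl in place of 4-(methoxymethyl)phenyl gives a number 7 percentage points lower from compound 1 to compound 4 (within the scatter), so the longer chain leaves the reading within the usual scatter. No supporting measurement speaks to the reason for this result.

From the compounds shown here alone, whether a 3-methoxypropyl chain, an amine or a carboxylic acid at this place would give a similar reading remains open. So does whether this change would behave the same way alongside pyridin-4-yl.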